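Methyl in place of chloro: expected clearance of compound 3

A few compounds are considered here, and "the series" means these few. Any claim that something is new, unique, unknown or untested is made for them only; others in the source may bear on it.

In an in vitro ADME assay on microsomes from liver (Mus musculus) for pharmacokinetics, read by LC-MS, with a stated time of 10 min, tested at 1 uM (a higher number here means faster removal of the compound, a lower number slower removal), compound 2 (`CN1C[C@H](C(=O)Nc2ccc(Cl)c(Cl)c2)[C@@H](c2ccc(/C=C/C(=O)Nc3ccccc3N)cc2)C1`) gives 36 mL/min/kg and stands highest of the two measured, above compound 1 (`CN1C[C@H](C(=O)Nc2ccc(Br)cc2)[C@@H](c2ccc(/C=C/C(=O)Nc3ccccc3N)cc2)C1`) at 16 mL/min/kg in the same read-out. Compound 3 (`Cc1cc(NC(=O)[C@H]2CN(C)C[C@@H]2c2ccc(/C=C/C(=O)Nc3ccccc3N)cc2)ccc1Cl`) carries methyl in place of chloro on an aromatic carbon, ortho to a chloro group. For the measured compounds named here, the one measured step bearing on this is a 2.3-fold higher number from compound 1 to compound 2 (0.35 log units; beyond the scatter) on the same aryl group, modest in size, and it gives no direction for methyl in place of chloro. No step beyond the scatter is therefore expected in this assay for this change. The expected step is a 1.1-fold lower number from compound 2 to compound 3 (0.05 log units; within the scatter) on this estimate. Compound 3 is estimated at 32 mL/min/kg with 16 mL/min/kg to 62 mL/min/kg as the expected range.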

Compound 3, clearance: 65 mL/min/kg
Beside the measured number, compound 3's estimate is 2.0-fold (0.31 log units) below it, outside the stated range (above it).
By their numbers in this assay, from the lowest: compound 1; then compounds 2 and 3 (each within the scatter of the next).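

In this assay, methyl in place of chloro, ortho to a chloro group, gives a 1.8-fold higher number from compound 2 to compound 3 (0.26 log units; within the scatter) and so does not separate the two groups at this position. Against the 4-bromophenyl amide, 4-chloro-3-methylphenyl gives a 4.1-fold higher number from compound 1 to compound 3 (0.61 log units; beyond the scatter) as a step that is read beyond the scatter, in the same direction as the step to 3,4-dichlorophenyl, a 2.3-fold higher number from compound 1 to compound 2 (0.35 log units; beyond the scatter) as printed. As far as these compounds go, the effect of an amine or a carboxylic acid at this position remains open. Nothing available explains these clearance numbers.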